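This account rests on a few compounds, and the source may have more. Where it says the series, first, only, none or still open, it means among the compounds named here.

Measured so far:
Compound 1, `CCCc1nc(-c2ccccc2)c(CNCCN2CCN(c3cccc(C(F)(F)F)c3)CC2)o1`: 1940 nM
Compound 2, `CCCc1nc(-c2ccccc2)c(CNCCCN2CCN(c3cccc(C(F)(F)F)c3)CC2)o1`: 650 nM
Compound 3, `CCCc1nc(-c2ccccc2)c(CNCCN2CCN(c3cccc(C)c3C)CC2)o1`: 1710 nM

All three were tested in an assay on HEK293 cells for inhibition of Voltage-dependent T-type calcium channel subunit alpha-1G (Homo sapiens), read by patch clamp; on this read-out higher numbers stand for weaker inhibition and lower numbers for stronger inhibition. Compound 2 gives the lowest of the three numbers; compound 3 and compound 1 both give higher numbers, and in each case the gap lies beyond the usual scatter, so compound 2 is the strongest inhibitor shown. Compound 4, `CCCc1nc(-c2ccccc2)c(CNCCCN2CCN(c3cccc(C)c3)CC2)o1`, has not yet been measured. It differs from compound 2 in one place: methyl in place of trifluoromethyl on an aromatic carbon.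

Going by the values given here, one measured step bears on this change, because it also swaps the group on that same aromatic ring while everything else stays the same: a 1.1-fold lower number from compound 1 to compound 3 (0.05 log units; within the scatter). That swap left the number essentially unchanged. On this basis the change from compound 2 to compound 4 is expected to move the number little, with a 1.2-fold higher number from compound 2 to compound 4 (0.06 log units; within the scatter), that is, nothing beyond the scatter. Compound 4 is therefore estimated at 750 nM, with a range from 300 nM to 2000 nM.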

Compound 4, half-maximal inhibitory concentration: 1190 nM
Compound 4: middle estimate off by 1.6-fold (0.20 log units), on the low side; the range from low to high includes it.
By their numbers in this assay, from the lowest: compounds 2, 4, 3 and 1 (each within the scatter of the next, the first and the last beyond it).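

In this assay, going by these compounds alone, this is the first swap of trifluoromethyl for methyl alone at this place on the aromatic ring, and it gives a 1.8-fold higher number from compound 2 to compound 4 (0.26 log units; within the scatter), a step that stays within the usual scatter. Replacing a group of four heavy atoms, three of them fluorine, with a single carbon therefore leaves compound 2 and compound 4 indistinguishable here, so this read-out gives no sign that the fluorine atoms are needed on this chain. Nothing available here offers an explanation for this result.

Going by these compounds, it remains open whether a chlorine atom, a methoxy group or a plain hydrogen at this same place would give a number clearly apart from these two. Also open, on these data alone, is whether a longer chain than that of compound 2 would keep or change this tolerance for either group.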